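This account rests on a few compounds, and the source may have more. Where it says the series, first, only, none or still open, it means among the compounds named here.

Measured so far:
compound 1 `Clc1cccc(-c2cc(-c3ccc(Cl)o3)cc(-c3cccs3)n2)c1`: 18100 nM
compound 2 `Clc1ccc(-c2cc(-c3cccnc3)nc(-c3ccsc3)c2)o1`: 21600 nM
compound 3 `Clc1ccc(-c2cc(-c3cccs3)nc(-c3ccccc3Cl)c2)o1`: 16800 nM

In a functional assay on DU-145 cells (Homo sapiens) for cytotoxicity, in the presence of a further agent that is not named here (on this read-out higher numbers stand for weaker inhibition and lower numbers for stronger inhibition), the three numbers sit within the scatter of one another, so compound 2 is not set apart from compound 1 or compound 3. Compound 4 `Clc1ccc(-c2cc(-c3ccc(Cl)o3)cc(-c3ccsc3)n2)cc1` differs from compound 2 by 4-chlorophenyl in place of pyridin-3-yl on an aromatic carbon. For the measured compounds named here, the only measured single-point step, a 1.1-fold lower number from compound 1 to compound 3 (0.03 log units; within the scatter), exchanges one chlorophenyl for another and does not test the exchange of pyridin-3-yl for 4-chlorophenyl; no measured pair does. Compound 1 and compound 3, each bearing a 3-chlorophenyl or 2-chlorophenyl group, give numbers close to that of compound 2. For compound 4 a step of a 1.3-fold lower number from compound 2 to compound 4 (0.10 log units; within the scatter) is therefore expected, nothing beyond the scatter. Compound 4 is estimated at 17000 nM, within 7000 nM to 40000 nM.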

Compound 4, half-maximal inhibitory concentration: 19500 nM
Compound 4: middle estimate off by 1.1-fold (0.06 log units), on the low side, and the stated range covers the measured number.
By their numbers in this assay, from the lowest: compounds 3, 1, 4 and 2 (each within the scatter of the next).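

In this assay the exchange of pyridin-3-yl for 4-chlorophenyl, on the aromatic carbon next to the ring nitrogen, gives a 1.1-fold lower number from compound 2 to compound 4 (0.04 log units; within the scatter) and so leaves the number unchanged within the scatter. This position therefore tolerates losing the hetero atom of the ring and its hydrogen-bond acceptor, a swap that the earlier step between two chlorophenyl groups did not test. Nothing available explains this flat result. On these data alone, whether an amine or a carboxylic acid on this ring would shift the number beyond the scatter stays open. No compound shown has a non-aromatic group at this position, such as a longer alkyl chain.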